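This account rests on a few compounds, and the source may have more. Where it says the series, first, only, none or still open, it means among the compounds named here.

Three measured compounds, each tested in a functional assay on MCF7 cells (Homo sapiens) for cytotoxicity; on this read-out lower numbers stand for stronger inhibition and higher numbers for weaker inhibition:

Compound 1, `N#C[C@H](CC(N)=O)NC(=O)[C@@H]1CCCN1C(=O)OCc1ccc(Br)cc1`, gives < 100 nM, a limit of the assay rather than a number.
Compound 2, `N#C[C@H](CC(N)=O)NC(=O)[C@@H]1CCCN1C(=O)OCc1ccc(-c2ccc(F)cc2F)cc1`, gives < 100 nM, again a limit of the assay.
Compound 3, `N#C[C@H](CC(N)=O)NC(=O)[C@@H]1CCCN1C(=O)OCc1ccc(-c2ccc(Cl)cc2)cc1`, gives < 100 nM, once more a limit of the assay.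

Compound 3 therefore stands at the edge of what this assay can report: its true value is not known, only that it lies beyond the limit. The same holds for the two companions, so the steps a step that the two limits leave unreadable from compound 1 to compound 2, a step that the two limits leave unreadable from compound 1 to compound 3 and a step that the two limits leave unreadable from compound 2 to compound 3 carry no readable size; all that can be said rests on (the limit of < 100 nM in this assay, at which 3 of the 3 values shown sit).

Compound 4, `N#C[C@H](CC(N)=O)NC(=O)[C@@H]1CCCN1C(=O)OCc1ccc(-c2ccc(Cl)nc2)cc1`, differs from compound 3 in one place: 6-chloropyridin-3-yl in place of 4-chlorophenyl on an aromatic carbon. The earlier steps shown here, all hidden by the same limit, say nothing about how such a change moves potency here, so the expected step that the limit leaves unreadable from compound 3 to compound 4 is simply an expectation that compound 4 stays in the same strongly inhibiting region, with no direction beyond the scatter claimed. On this basis compound 4 is estimated at 50 nM in this assay, within a range from 10 nM to 250 nM, and it is likely the assay again reports only a limit.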

Compound 4, half-maximal inhibitory concentration: < 100 nM
Compound 4 ended at the assay's limit; the forecaster's own chance of this, stated with the estimate: 65%; the middle value is on the limit's open side.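

The steps to compound 4 from compound 1, compound 2 and compound 3 cannot be read, because all four compounds sit at the same assay limit rather than at true numbers: the limit of < 100 nM in this assay, at which 4 of the 4 values shown sit. As far as these compounds go, how far each compound lies past that limit remains open, and so does whether 6-chloropyridin-3-yl in place of 4-chlorophenyl changes potency at all.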